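Swapping a butyl chain for methylsulfanyl on a weak aorta inhibitor

A few compounds are considered here, and "the series" means these few. Any claim that something is new, unique, unknown or untested is made for them only; others in the source may bear on it.

Compound 1, `N#Cc1ccccc1Cn1nc(-c2ccc(CO)o2)c2ccccc21`: 8700 nM
Compound 2, `CCCCc1cnc(-c2nn(Cc3ccccc3F)c3ncccc23)nc1N`: 218000 nM

Of the compounds shown here, two have been tested in a functional assay (aorta) with Oryctolagus cuniculus as the target; on this read-out lower numbers stand for stronger inhibition and higher numbers for weaker inhibition. Compound 1 `N#Cc1ccccc1Cn1nc(-c2ccc(CO)o2)c2ccccc21` gives 8700 nM, whereas compound 2 `CCCCc1cnc(-c2nn(Cc3ccccc3F)c3ncccc23)nc1N` gives 218000 nM, the highest of the two numbers; the nearest measured compound, compound 1, stands a long way below it, well beyond the scatter of repeated measurements. Compound 2 is therefore the weaker of the pair in this assay.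

The next compound, compound 3 `CSc1cnc(-c2nn(Cc3ccccc3F)c3ncccc23)nc1N`, keeps the whole framework of compound 2 and differs only at one aromatic carbon: methylsulfanyl in place of butyl on an aromatic carbon. Going by the values given here, no step between measured compounds involving this change is available, so there is nothing measured to anchor its effect. With compound 2 already so far from the region of compound 1, the change is expected to move the number only moderately, and a shift in either direction would not be surprising. The step from compound 2 to compound 3 is expected to be a 1.5-fold lower number from compound 2 to compound 3 (0.16 log units; within the scatter), within or little beyond the scatter. Compound 3 is estimated at 150000 nM, with a likely range from 30000 nM to 700000 nM in this assay.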

Compound 3, half-maximal inhibitory concentration: 243000 nM
For compound 3 the middle estimate is 1.6-fold (0.21 log units) below the measured one; the measured number falls inside the stated range.
By their numbers in this assay, from the lowest: compound 1; then compounds 2 and 3 (each within the scatter of the next).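

In this assay, going by these compounds alone, methylsulfanyl in place of butyl on the aromatic carbon ortho to the amino group gives (a 1.1-fold higher number from compound 2 to compound 3 (0.05 log units; within the scatter)), so this pair offers the first measured reading at this position. The read-out does not separate the two groups, even though they differ in what is counted for them: butyl has four carbons and no hydrogen-bond acceptor, whereas methylsulfanyl has two heavy atoms, one of them sulfur, and one hydrogen-bond acceptor. Nothing available accounts for this lack of separation.

A single step with two neutral, ring-free groups cannot show whether this carbon is insensitive to substitution in general, and a carboxylic acid, a dimethylamino group or a longer chain such as hexyl could still separate from butyl on this read-out. The compounds shown also leave open whether the same swap would give a comparable step on another core, as the pair shares just one framework.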